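Amino in place of methyl on a shared nucleoside core

The source may hold more compounds than are shown below. What is called first, only, known or untested is meant among the compounds shown, and "the series" means these compounds.

Compound 1 `Nc1nc(N)c2c(-c3ccsc3)cn([C@@H]3O[C@H](CO)[C@@H](O)[C@H]3O)c2n1` — > 20000 nM
Compound 2 `COc1nc(N)nc2c1c(-c1ccccc1)cn2[C@@H]1O[C@H](CO)[C@@H](O)[C@H]1O` — > 20000 nM
Compound 3 `Cc1nc(N)c2c(-c3ccccc3)cn([C@@H]3O[C@H](CO)[C@@H](O)[C@H]3O)c2n1` — > 20000 nM

Of the compounds shown here, three have been tested in a functional assay on HepG2 cells (Homo sapiens) for antiproliferative activity, read by XTT assay, with a stated time of 72 h; a lower number here means a stronger inhibitor, a higher number a weaker inhibitor. In this assay compound 1 gives > 20000 nM, which is a limit of the assay rather than a number. In this assay compound 2 also gives > 20000 nM, again a limit. In this assay compound 3 gives > 20000 nM, once more a limit. So compound 3 stands where every measured compound stands: at the limit of > 20000 nM in this assay, at which 3 of the 3 values shown sit. No difference between any two of them can be read from these values.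

Compound 4 `Nc1nc(N)c2c(-c3ccccc3)cn([C@@H]3O[C@H](CO)[C@@H](O)[C@H]3O)c2n1` has not yet been measured. It differs from compound 3 in one place: amino in place of methyl on an aromatic carbon. Compound 1 already carries two amino groups on its six-membered ring, and in this assay compound 1 gives > 20000 nM, a limit. The expected step from compound 3 to compound 4 is therefore a number no higher from compound 3 to compound 4 (the limit leaves the size open), that is, no change beyond the scatter and most likely another limit. Compound 4 is expected to give 20000 nM in this assay, within a range from 6000 nM to 60000 nM.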

Compound 4, half-maximal inhibitory concentration: > 20000 nM
Compound 4 ended at the assay's limit; the forecaster's own chance of this, stated with the estimate: 80%; the middle value lies on the limit itself.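

Going by these compounds alone, no step from compound 1, compound 2 or compound 3 to compound 4 can be read, because each of the four values is a limit of the assay and not a number: the limit of > 20000 nM in this assay, at which 4 of the 4 values shown sit.

The compounds shown leave open how strong each one really is, and whether amino, methyl, methoxy, phenyl or thiophen-3-yl makes any difference on the shared core.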